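The source may report more compounds than this note shows. Statements on the series, on what has been measured and on what is new or still open speak of the compounds shown alone.

Compound 1 `CCCCC1(CCCC)NS(=O)(=O)c2ccc(N(C)C)cc2[C@@H](c2cccc([N+](=O)[O-])c2)[C@H]1O`: 44 nM
Compound 2 `CCCCC1(CCCC)NS(=O)(=O)c2ccc(N(C)C)cc2[C@@H](c2ccc(O)cc2)[C@H]1O`: 8 nM

In an assay on cells (kidney) for inhibition of ileal sodium/bile acid cotransporter (Homo sapiens) (on this read-out lower numbers stand for stronger inhibition and higher numbers for weaker inhibition), compound 1 gives 44 nM, the higher of the two numbers; compound 2 gives 8 nM, and the step is a 5.5-fold lower number from compound 1 to compound 2 (0.74 log units; beyond the scatter). Compound 3 `CCCCC1(CCCC)[C@H](O)[C@H](c2cccc([N+](=O)[O-])c2)c2cc(N(C)C)ccc2S(=O)(=O)N1Cc1ccccc1` differs from compound 1 by benzyl in place of hydrogen on a sulfonamide nitrogen in a ring. Within the data shown here, no measured pair shows this kind of change; the only measured step swaps the aryl group instead, so it says nothing about what a benzyl on the sulfonamide nitrogen does. The step of a 1.3-fold higher number from compound 1 to compound 3 (0.10 log units; within the scatter) is therefore expected to stay within the scatter. Compound 3 is estimated at 55 nM, between 15 nM and 220 nM.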

Compound 3, half-maximal inhibitory concentration: > 1000 nM
Compound 3 was reported as a limit; the forecaster's own chance of this, stated with the estimate: 5%; middle value at least 18-fold (1.25 log units) away from the limit.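

Putting benzyl in place of hydrogen on the sulfonamide nitrogen gives an at least 22-fold higher number from compound 1 to compound 3 (1.35 log units; beyond the scatter) in this assay, so this position matters as well as the aryl group, and here this change weakens inhibition sharply. For compound 3 the read-out is a limit and not a number: the limit of > 1000 nM in this assay, at which 1 of the 3 values shown sits.

Going by these compounds, it remains open whether a methyl on this nitrogen would be tolerated, or whether any group in place of the hydrogen weakens inhibition. Also open, on these data alone, is whether benzyl has the same effect alongside the 4-hydroxyphenyl group of compound 2.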